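Cytotoxicity notes: chloro replacing trifluoromethoxy in the series

A few compounds are considered here, and "the series" means these few. Any claim that something is new, unique, unknown or untested is made for them only; others in the source may bear on it.

Of the compounds shown here, three have been read in an ADME assay on MRC5 cells (Homo sapiens) for cytotoxicity, read by fluorescence and resazurin assay, with a stated time of 3 days; on this read-out lower numbers stand for stronger inhibition and higher numbers for weaker inhibition. Compound 1 `Cc1cccc(Oc2cccc(CN3CCC(n4cc(C)c(=O)[nH]c4=O)CC3)c2)c1` reaches only an assay limit, > 64000 nM, namely (the limit of > 64000 nM in this assay, at which 1 of the 3 values shown sits). Compound 2 `Cc1cn(C2CCN(Cc3cccc(Oc4ccc(Cl)cc4)c3)CC2)c(=O)[nH]c1=O` gives 25100 nM in this assay, and compound 3 `Cc1cn(C2CCN(Cc3cccc(Oc4cccc(OC(F)(F)F)c4)c3)CC2)c(=O)[nH]c1=O` gives 5260 nM. Compound 3 therefore stands at the lowest of the two numbers: a 4.8-fold lower number from compound 2 to compound 3 (0.68 log units; beyond the scatter), and an at least 12-fold lower number from compound 1 to compound 3 (1.08 log units; beyond the scatter), both beyond the scatter; between the other two, an at least 2.5-fold lower number from compound 1 to compound 2 (0.40 log units; beyond the scatter).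

Compound 4 `Cc1cn(C2CCN(Cc3cccc(Oc4cccc(Cl)c4)c3)CC2)c(=O)[nH]c1=O` differs from compound 3 in one place: chloro in place of trifluoromethoxy on an aromatic carbon. Within the data shown here, two measured steps bear on it. The reverse of the move from compound 2 to compound 3 exchanges a chlorophenyl for the trifluoromethoxyphenyl and was worth the modest step of a 4.8-fold lower number from compound 2 to compound 3 (0.68 log units; beyond the scatter), and the entry of trifluoromethoxy in place of methyl gave the large step of an at least 12-fold lower number from compound 1 to compound 3 (1.08 log units; beyond the scatter). Removing trifluoromethoxy in favour of chloro is therefore expected to raise the number in this assay by a modest amount, short of the limit.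

Compound 4 is estimated at 15000 nM, with a range of 5000 nM to 45000 nM. That estimate means an expected step of a 2.9-fold higher number from compound 3 to compound 4 (0.46 log units; beyond the scatter).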

Compound 4, half-maximal inhibitory concentration: 21000 nM
For compound 4 the middle estimate is 1.4-fold (0.15 log units) below the measured one; the measured number falls inside the stated range.
By their numbers in this assay, from the lowest: compound 3; then compounds 4 and 2 (each within the scatter of the next). At a limit, above all of these: compound 1.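

On the aromatic carbon meta to a large group, the direct exchange in this assay gives a 4.0-fold higher number from compound 3 to compound 4 (0.60 log units; beyond the scatter), whereas moving the chloro gives a 1.2-fold lower number from compound 2 to compound 4 (0.08 log units; within the scatter), so the two chlorophenyl compounds do not separate and the trifluoromethoxy of compound 3 stands apart from both. Within these compounds, the change from trifluoromethoxy to chloro therefore matters more than the placing of the chloro, and this holds for this pair of substituents only. Chloro in place of methyl gives an at least 3.0-fold lower number from compound 1 to compound 4 (0.48 log units; beyond the scatter), which shows that even the chloro compound lies on the lower side of the methyl compound, though the size of that step stays open-ended, as compound 1 gives only a limit: the limit of > 64000 nM in this assay, at which 1 of the 4 values shown sits.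

From the compounds shown here alone, whether a different group on this aromatic carbon, such as a nitrile, an amine or a carboxylic acid, would read like chloro or like trifluoromethoxy remains open. Also open is how trifluoromethoxy would read in the place that chloro holds in compound 2, and the compounds shown give no account of why the exchange from trifluoromethoxy to chloro has the size it has.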